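This account rests on a few compounds, and the source may have more. Where it says the series, first, only, none or still open, it means among the compounds named here.

Compound 1 `CC(C)n1c(/C=C2\SC(=O)N(CC(=O)N3CCOCC3)C2=O)nc2ccccc21` and compound 2 `CC(C)n1c(/C=C2\SC(=O)N(CC(=O)N3CCCCC3)C2=O)nc2ccccc21` share one core and differ only at the amide. In a functional assay on PC-3 cells (Homo sapiens) for inhibition, read by MTT assay, with a stated time of 48 h (on this read-out higher numbers stand for weaker inhibition and lower numbers for stronger inhibition), compound 1 gives only the limit > 50000 nM. In this assay compound 2 likewise gives only the limit > 50000 nM. The step that the two limits leave unreadable from compound 1 to compound 2 is therefore unreadable, both values sitting at the limit of > 50000 nM in this assay, at which 2 of the 2 values shown sit. Compound 3 `CC(C)n1c(/C=C2\SC(=O)N(CC(=O)Nc3cc(C(C)(C)C)on3)C2=O)nc2ccccc21` carries (5-(tert-butyl)-1,2-oxazol-3-yl)amino in place of piperidin-1-yl on a carbonyl carbon. Within the data shown here, no measured step bears readably on this change, so no direction beyond the scatter can be drawn from the series. Compound 3 is expected to give 60000 nM, with a range from 15000 nM to 200000 nM. The step this estimate means is a step that the limit leaves unreadable from compound 2 to compound 3, most probably again reported as a limit.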

Compound 3, half-maximal inhibitory concentration: > 50000 nM
Compound 3 was reported as a limit; the forecaster's own chance of this, stated with the estimate: 80%; the middle value does not contradict the limit.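

No new step can be read for compound 3 against compound 1 or compound 2, each value being a limit and not a number: the limit of > 50000 nM in this assay, at which 3 of the 3 values shown sit. The compounds shown leave open which amide group, if any, would give a readable value in this assay.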